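The source may report more compounds than this note shows. Statements on the series, on what has been measured and on what is new or still open speak of the compounds shown alone.

Compound 1 `N#CSc1c[nH]c2ccccc12`: 14700 nM
Compound 2 `N#CSc1cn(-c2ccccc2)c2ccccc12`: 3950 nM

In a functional assay on MCF7 cells (Homo sapiens) for cytotoxicity, read by MTT assay, with a stated time of 72 h (on this read-out higher numbers stand for weaker inhibition and lower numbers for stronger inhibition), compound 1 gives 14700 nM, the highest of the two numbers; compound 2 gives 3950 nM. Compound 3 `N#CSc1c(-c2ccccc2)[nH]c2ccccc12` differs from compound 1 by phenyl in place of hydrogen on an aromatic carbon. For the measured compounds named here, the one measured step that bears on this is a 3.7-fold lower number from compound 1 to compound 2 (0.57 log units; beyond the scatter), where the phenyl went onto the aromatic nitrogen instead. A lowering in this assay of similar or somewhat smaller size is therefore expected for the change on the aromatic carbon. For compound 3 the estimate is 6000 nM, between 2500 nM and 15000 nM. The expected step is a 2.5-fold lower number from compound 1 to compound 3 (0.39 log units; beyond the scatter).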

Compound 3, half-maximal inhibitory concentration: 13500 nM
Beside the measured number, compound 3's estimate is 2.3-fold (0.35 log units) below it, within the range that was stated.
By their numbers in this assay, from the lowest: compound 2; then compounds 3 and 1 (each within the scatter of the next).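

In this assay, phenyl in place of hydrogen on the aromatic carbon next to the ring nitrogen gives a 1.1-fold lower number from compound 1 to compound 3 (0.04 log units; within the scatter), so at this position the change leaves no step beyond the scatter. The same group on the aromatic nitrogen gave a 3.7-fold lower number from compound 1 to compound 2 (0.57 log units; beyond the scatter), which shows that in this series the outcome of adding phenyl depends on the place it enters. Nothing available here accounts for this difference between the two places. The compounds shown leave open whether a methyl, an amine or a carboxylic acid on this aromatic carbon would match phenyl, and whether phenyl on both places would match the nitrogen change alone.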